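The source may hold more compounds than are shown below. What is called first, only, known or untested is meant among the compounds shown, and "the series" means these compounds.

In an assay on CHO cells for antagonist activity at transient receptor potential cation channel subfamily V member 1 (Homo sapiens), read by FLIPR and calcium flux (on this read-out lower numbers stand for stronger inhibition and higher numbers for weaker inhibition), compound 1 `CCCCCCc1nc(C(F)(F)F)ccc1CNC(=O)C(C)c1ccc(NS(C)(=O)=O)c(F)c1` gives 1.6 nM, the highest number of the three measured compounds. Going by the values given here, compound 2 `CCC1CCC(c2nc(C(F)(F)F)ccc2CNC(=O)[C@@H](C)c2ccc(NS(C)(=O)=O)c(F)c2)CC1` gives 0.2 nM and compound 3 `C[C@H](C(=O)NCc1ccc(C(F)(F)F)nc1C1CCC(C)(C)CC1)c1ccc(NS(C)(=O)=O)c(F)c1` gives 0.3 nM; both gaps to compound 1 lie beyond the usual scatter, while the only single change recorded, a 1.5-fold higher number from compound 2 to compound 3 (0.18 log units; within the scatter), lies within it. Compound 4 `CC1C=C(c2nc(C(F)(F)F)ccc2CNC(=O)C(C)c2ccc(NS(C)(=O)=O)c(F)c2)CCC1` differs from compound 1 in one place: 3-methylcyclohex-1-en-1-yl in place of hexyl on an aromatic carbon. Among the compounds with values here, no measured step swaps a chain for a ring at this position, so the exchange itself is unprobed. What the numbers do show is that the two compounds carrying a six-membered ring there, compound 2 and compound 3, sit well below compound 1, and that changing the substituents on that ring hardly matters. Compound 4 also carries a six-membered ring at this position, so a lower number than compound 1 is expected, of roughly the size separating compound 1 from the ring-bearing pair, giving a 4.0-fold lower number from compound 1 to compound 4 (0.60 log units; beyond the scatter). Compound 4 is therefore estimated at 0.4 nM, within a range of 0.15 nM to 1.2 nM.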

Compound 4, inhibition constant: 0.2 nM
For compound 4 the middle estimate is 2.0-fold (0.30 log units) above the measured one; low and high end bracket the measured number.
By their numbers in this assay, from the lowest: compounds 2, 4 and 3 (each within the scatter of the next); then compound 1.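

The step of an 8.0-fold lower number from compound 1 to compound 4 (0.90 log units; beyond the scatter) is a direct reading of a chain giving way to a ring at this position, and its size is beyond the scatter. The number for compound 4 also lies within the scatter of those for compound 2 and compound 3, so a ring with a double bond outside aromatic rings gives numbers indistinguishable from those of the two saturated rings. No measurement shown here explains why the ring gives the lower number.

From the compounds shown here alone, the step changes the chain to a ring, adds a methyl group and brings in a double bond all at once, so the share of each remains open. Also open, going by these compounds, is how a phenyl group or a piperidinyl group would behave at this position.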